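The source may report more compounds than this note shows. Statements on the series, on what has been measured and on what is new or still open speak of the compounds shown alone.

Compound 1, `CCCNc1nnc(SCC(=O)N(Cc2cccc([N+](=O)[O-])c2)c2ccc(F)cc2)s1`, gives 42.7% in an assay on isolated protein for inhibition of Amine oxidase [flavin-containing] B (Homo sapiens), read by fluorescence and Amplex Red, with a stated time of 30 min, tested at 1 mM; a higher number here means a stronger effect of the compound at the concentration tested, a lower number a weaker effect.
Compound 2, `CCNc1nnc(SCC(=O)N(Cc2cccc([N+](=O)[O-])c2)c2ccc(F)cc2)s1`, gives 41.3% in this assay.
Compound 3, `CC(C)CNc1nnc(SCC(=O)N(Cc2cccc([N+](=O)[O-])c2)c2ccc(F)cc2)s1`, gives 36% in this assay.

Compound 3 carries the lowest of the three numbers, yet it is not set apart from the others: the step of a number 5.3 percentage points lower from compound 2 to compound 3 (within the scatter) and the step of a number 6.7 percentage points lower from compound 1 to compound 3 (within the scatter) both fall within the scatter, and the same holds for a number 1.4 percentage points lower from compound 1 to compound 2 (within the scatter). Across these three compounds, changes to the alkyl group on the nitrogen on the aromatic ring have left this assay essentially unmoved.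

Compound 4, `CC(C)Nc1nnc(SCC(=O)N(Cc2cccc([N+](=O)[O-])c2)c2ccc(F)cc2)s1`, is not yet measured. It differs from compound 3 by isopropyl in place of isobutyl on a nitrogen on an aromatic ring. Among the compounds with values here, the step that bears most directly on this change is the one from compound 2 to compound 3, where isopropyl replaced methyl on the saturated chain carbon bound to the nitrogen on the aromatic ring; that step stayed within the scatter. The two remaining steps, each also a trimming or lengthening of the same alkyl group, likewise stayed within the scatter. Compound 4 is therefore expected to show a step of a number 3 percentage points higher from compound 3 to compound 4 (within the scatter), that is, no movement beyond the scatter. The estimate for compound 4 in this assay is 39%, with a range from 27% to 51%.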

Compound 4, a percentage reported as inhibition, at one concentration (the size of the read-out at that concentration, not a potency): 36%
Estimate against measurement, compound 4: 3 percentage points above; the measured number falls inside the stated range.
By their numbers in this assay, from the lowest: compounds 3, 4, 2 and 1 (each within the scatter of the next).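

In this assay, isopropyl in place of isobutyl on the nitrogen on an aromatic ring gives no change at the digits printed from compound 3 to compound 4 (within the scatter), and the two other new steps, a number 5.3 percentage points lower from compound 2 to compound 4 (within the scatter) and a number 6.7 percentage points lower from compound 1 to compound 4 (within the scatter), stay equally flat. Ethyl, propyl, isobutyl and isopropyl on this nitrogen therefore cannot be told apart here, and no trend with chain size appears among these four compounds. The added compound also lets one change, methyl in place of hydrogen, be read a second time, and it behaves alike on both cores: the same change on two cores in this assay, a number 6.7 percentage points lower (within the scatter) from compound 1 to compound 3 and a number 5.3 percentage points lower (within the scatter) from compound 2 to compound 4, 1.4 percentage points apart, within the scatter of two such steps.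

As far as these compounds go, all four groups are small saturated alkyl chains, so it remains open how this position would respond to a cyclohexyl ring, a benzyl group or a chain ending in a carboxylic acid. Each reading also comes from a single concentration with the rest of the shared core held fixed, which leaves open both the potency of these compounds and whether changes elsewhere on the core would move the number beyond the scatter.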